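The source may hold more compounds than are shown below. What is called first, only, known or untested is meant among the compounds shown, and "the series" means these compounds.

Compound 1 `COc1cc(/C=C/C(=O)c2cccc(-n3cc(-c4ccc(Cl)cc4)[nH]c3=O)c2)ccc1O` is one of two compounds examined in a functional assay on U-251 cells (Homo sapiens) for inhibition; a lower number here means a stronger inhibitor of growth, a higher number a weaker inhibitor of growth; there compound 1 gives 2230 nM, the higher of the two numbers. The other, compound 2 `COc1cc(/C=C/C(=O)c2cccc(-n3cc(-c4ccccc4)[nH]c3=O)c2)cc(OC)c1OC`, carries a different set of groups on the shared core and gives 630 nM, a gap beyond the usual scatter, though compound 2 differs from compound 1 in more than one place. Compound 3 `COc1cc(/C=C/C(=O)c2cccc(-n3cc(-c4ccccc4)[nH]c3=O)c2)ccc1O` arises from compound 1 by a single change: hydrogen in place of chloro on an aromatic carbon, so the 4-chlorophenyl becomes a phenyl. Among the compounds with values here, no measured pair isolates this change, so only a modest move toward a lower number is expected, a 1.5-fold lower number from compound 1 to compound 3 (0.17 log units; within the scatter), near the edge of scatter. The estimate for compound 3 is 1500 nM, between 600 nM and 4000 nM.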

Compound 3, concentration for 50% growth inhibition: 2110 nM
For compound 3 the middle estimate is 1.4-fold (0.15 log units) below the measured one; measured number inside the range.
By their numbers in this assay, from the lowest: compound 2; then compounds 3 and 1 (each within the scatter of the next).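

In this assay, within the data shown here, the change from 4-chlorophenyl to phenyl amounts to a 1.1-fold lower number from compound 1 to compound 3 (0.02 log units; within the scatter) and is the first single change that can be read here. At this place on the aromatic ring, hydrogen can stand in for chloro with no change in growth inhibition beyond the scatter. Nothing shown explains this result. Going by these compounds, it remains open whether an amine or a carboxylic acid at this place would shift the number, and whether the same swap would behave alike with different groups elsewhere on the shared core.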